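Methoxy for fluoro on the core of compound 1

The source may hold more compounds than are shown below. What is called first, only, known or untested is meant among the compounds shown, and "the series" means these compounds.

Compound 1 `CC[C@H](c1ccc(C(=O)O)c(Oc2cccc(Cl)c2)c1F)N1CCC[C@H](n2cc(C)c(=O)[nH]c2=O)C1` gives 0.12 in a physicochemical assay for lipophilicity, using the shake flask method, in phosphate buffer, measured as octanol-water partition, at pH 7.4 (a higher number here means a more lipophilic compound, a lower number a more polar compound), the lowest of the three numbers measured. Compound 3 `CC[C@@H](c1ccc(C(=O)O)c(Oc2cccc(Cl)c2)c1)N1CCC[C@H](n2cc(C)c(=O)[nH]c2=O)C1` gives 0.22 in this assay, a number within the scatter of that of compound 1, while compound 2 `Cc1cn([C@H]2CCCN([C@@H](CC(C)C)c3ccc(C(=O)O)c(Oc4cccc(Cl)c4)c3F)C2)c(=O)[nH]c1=O` gives 0.57, a number beyond the scatter above it. Compound 4 `CC[C@H](c1ccc(C(=O)O)c(Oc2cccc(Cl)c2)c1OC)N1CCC[C@H](n2cc(C)c(=O)[nH]c2=O)C1` differs from compound 1 in one place: methoxy in place of fluoro on an aromatic carbon. Within the data shown here, no step between measured compounds is known for this change. Compound 4 is expected to show no step beyond the scatter, with a number 0.03 log units higher from compound 1 to compound 4 (within the scatter), the change being estimated as small. The estimate for compound 4 is 0.15, within a range from -0.3 to 0.6.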

Compound 4, distribution coefficient: -0.13
Estimate against measurement, compound 4: 0.28 log units above, within the range that was stated.
By their numbers in this assay, from the lowest: compounds 4, 1 and 3 (each within the scatter of the next, the first and the last beyond it); then compound 2.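

In this assay, among these compounds, methoxy in place of fluoro on this aromatic carbon, ortho to a 3-chlorophenoxy group, gives a number 0.25 log units lower from compound 1 to compound 4 (within the scatter), the only step known for this change. Among the compounds shown here, the earlier compounds all carried fluoro or no substituent here, so this is the first sign that a group with a hydrogen-bond acceptor can sit at this position without a step beyond the scatter. No measured finding bears on why the step has this size.

As far as these compounds go, an ethoxy group, a hydroxy group or an amine at this position remains open. So does the same change on compound 2, which also carries fluoro here.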